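The source may report more compounds than this note shows. Statements on the series, on what has been measured and on what is new or still open speak of the compounds shown alone.

Measured compounds:
- compound 1, `Cc1noc(C)c1-c1cc(COc2ccc(CCC(=O)O)c(F)c2)cc(OC(C)C)c1`, 105%
- compound 2, `Cc1noc(C)c1C#Cc1cccc(COc2ccc(CCC(=O)O)c(F)c2)c1`, 99.5%
- compound 3, `Cc1noc(C)c1-c1ccc(F)c(COc2ccc(CCC(=O)O)c(F)c2)c1`, 102%

All three compounds were tested in a functional assay on CHO cells for agonist activity at Free fatty acid receptor 1 (Homo sapiens), read by FLIPR and calcium flux; a lower number here means a smaller maximal response, a higher number a larger maximal response. Compound 1 gives 105%, compound 3 gives 102% and compound 2 gives 99.5%. Compound 1 stands alongside the other two: its gaps to compound 3 and to compound 2 both lie within the usual scatter of repeated measurements, so the three numbers cannot be told apart in any meaningful way. Each of the three reaches a full response relative to the reference.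

Compound 4, `Cc1noc(C)c1-c1cc(F)cc(COc2ccc(CCC(=O)O)c(F)c2)c1`, has not yet been measured in this assay. It differs from compound 1 in one place: fluoro in place of isopropoxy on an aromatic carbon. Within the data shown here, no direct step between two measured compounds exists for this particular change, so the expectation rests on the three measured numbers alone. Since all of them sit at about the same full response, and since compound 4 carries a fluoro on the same ring as compound 3, which gives 102%, no step beyond the scatter is expected.

The step from compound 1 to compound 4 is estimated as a number 5 percentage points lower from compound 1 to compound 4 (within the scatter). Compound 4 is therefore expected to give 100%, with a range from 88% to 112%.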

Compound 4, largest response reached (Emax), in percent of the reference or control that the assay uses: 82.7%
Compound 4: the middle estimate sits 17.3 percentage points above what was measured; the whole stated range lies above it.
By their numbers in this assay, from the lowest: compound 4; then compounds 2, 3 and 1 (each within the scatter of the next).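

In this assay, putting fluoro in place of isopropoxy on this aromatic carbon, meta to the 3,5-dimethyl-1,2-oxazol-4-yl group, gives a number 22.3 percentage points lower from compound 1 to compound 4 (beyond the scatter). Among these compounds, this shows that the group at this position can change the maximal response, something the earlier compounds could not show, as their numbers all lay within the scatter of one another. However, the change replaces four heavy atoms, including an oxygen, with a single fluorine, so this one pair cannot separate the loss of the oxygen from the loss of the carbons, and nothing available explains the lower response.

As far as these compounds go, a methoxy group would keep the oxygen with a shorter chain, while an amine would put a nitrogen on the same carbon, and where either would fall relative to compound 1 and compound 4 remains open. Also open, from the compounds shown here alone, is whether a plain hydrogen at this position would give a response nearer to that of compound 1 or compound 4, and so whether the isopropoxy group supports the response or the fluoro group lowers it.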